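The compounds below may be only part of what the source reports. "The series", "measured", "known", "first", "only" and "open" are said of these compounds alone.

Four compounds built on a shared core are considered here. Compound 1 `CC1=C(C(=O)OCc2ccccc2)C(c2ccco2)NC(=O)N1` carries furan-2-yl on a saturated ring carbon, and compound 2 `CC1=C(C(=O)OCc2ccccc2)C(c2ccoc2)NC(=O)N1` carries furan-3-yl in its place. Compound 3 `CC1=C(C(=O)CC(C)C)C(c2ccco2)NC(=O)N1` keeps the furan-2-yl but bears an isobutylcarbonyl group, and compound 4 `CC1=C(C(=O)CC(C)C)C(c2ccoc2)NC(=O)N1` pairs that isobutylcarbonyl group with furan-3-yl. In an assay on membranes from HEK293 cells for displacement of a labelled ligand from adenosine receptor A2b (Homo sapiens), read by scintillation counting, with a stated time of 30 min (on this read-out higher numbers stand for weaker inhibition and lower numbers for stronger inhibition), compound 1 gives 887 nM, compound 2 gives 6650 nM and compound 3 gives 240 nM. The difference between the core of compound 1 and the core of compound 3 is not broken down here; compound 3 simply stands lowest of the three measured compounds.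

The measured pair shows what the furan swap does: the change furan-3-yl in place of furan-2-yl on a saturated ring carbon brought a 7.5-fold higher number from compound 1 to compound 2 (0.87 log units; beyond the scatter). The change furan-3-yl in place of furan-2-yl on a saturated ring carbon is the same kind of change. Its surroundings read slightly differently, since the saturated ring carbon in compound 3 sits next to the ring atom that bears an isobutylcarbonyl group, whereas in compound 1 that ring atom bears a large group; otherwise the words describing the place agree.

Among the compounds with values here, on that footing the swap in compound 4 is expected to give a 7.1-fold higher number from compound 3 to compound 4 (0.85 log units; beyond the scatter), because a 7.5-fold higher number from compound 1 to compound 2 (0.87 log units; beyond the scatter) is the only measured guide for this change. Compound 4 is therefore estimated at 1700 nM, and it is expected to fall between 600 nM and 5000 nM.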

Compound 4, inhibition constant: 1010 nM
Beside the measured number, compound 4's estimate is 1.7-fold (0.23 log units) above it, within the range that was stated.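

On the core of compound 3, putting furan-3-yl in place of furan-2-yl on the saturated ring carbon gave a 4.2-fold higher number from compound 3 to compound 4 (0.62 log units; beyond the scatter) in this assay, the same direction as the step already seen on the core of compound 1. Set side by side, the two steps do not separate from each other, and the size of the change can be treated as shared by these two cores: the same change on two cores in this assay, a 7.5-fold higher number (0.87 log units; beyond the scatter) from compound 1 to compound 2 and a 4.2-fold higher number (0.62 log units; beyond the scatter) from compound 3 to compound 4, 1.8-fold (0.25 log units) apart, within the scatter of two such steps. This shows that the change carried over from one core to the other in this series in both direction and size, with furan-2-yl giving the lower number in each pair, but it rests on two pairs in a single read-out and does not show that the same step would appear on any further core, nor does it explain why the two furans differ.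

The compounds shown leave open whether the step would persist with a different group in place of the isobutylcarbonyl group, such as a longer alkyl chain or a carboxylic acid. They also leave open how a phenyl group or a thiophen-2-yl group on the saturated ring carbon would compare with either furan on these cores.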